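Oxadiazoles with a Para-Substituted Phenyl Ring Tested for Antiproliferation

The source may hold more compounds than are shown below. What is called first, only, known or untested is meant among the compounds shown, and "the series" means these compounds.

Measured compounds:
compound 1, `c1ccc(-c2noc(-c3ccncc3)n2)cc1`, 710000 nM
compound 2, `COc1ccc(-c2noc(-c3ccc(F)cc3)n2)cc1O`, > 1000000 nM
compound 3, `COc1cc(-c2noc(-c3ccncc3)n2)ccc1OCc1ccccc1`, > 1000000 nM

In a functional assay on LNCaP cells (Homo sapiens) for antiproliferative activity, read by MTT assay, with a stated time of 24 h (a lower number here means a stronger inhibitor, a higher number a weaker inhibitor), compound 1 gives 710000 nM. Compound 2 reaches only a limit of the assay, > 1000000 nM. Compound 3 likewise sits at a limit, > 1000000 nM. Compound 2 therefore stands at the limit of > 1000000 nM in this assay, at which 2 of the 3 values shown sit, with no number of its own.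

The unmeasured compound 4, `COc1ccc(-c2noc(-c3ccc(F)cc3)n2)cc1OC1CCCC1`, differs from compound 2 by cyclopentyl in place of hydrogen on an oxygen on an aromatic ring. Going by the values given here, no step between two measured compounds is available to guide this change. Since compound 2 sits at a limit, and compound 3 with a benzyl group on the corresponding oxygen also sits at a limit, no shift beyond the scatter is expected for the step of an at least 1.1-fold lower number from compound 2 to compound 4 (0.04 log units; that floor lies within the scatter). Compound 4 is estimated at 900000 nM, within 300000 nM to 3000000 nM.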

Compound 4, half-maximal inhibitory concentration: 87900 nM
For compound 4 the middle estimate is 10-fold (1.01 log units) above the measured one, and the stated range ends above it.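

In this assay, cyclopentyl in place of hydrogen on an oxygen on an aromatic ring gives an at least 11-fold lower number from compound 2 to compound 4 (1.05 log units; beyond the scatter), so this position can carry a change that moves the read-out beyond the scatter. Among the compounds shown, this is the first such step at this position. Its size is only a floor, since compound 2 has no number of its own: the limit of > 1000000 nM in this assay, at which 2 of the 4 values shown sit.

Going by these compounds, whether a methyl group, a longer chain such as butyl or a chain ending in an amine on this oxygen would give a similar step remains open.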